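The source may hold more compounds than are shown below. What is called first, only, known or untested is meant among the compounds shown, and "the series" means these compounds.

Working notes on the series.

The shared core carries a variable aryl group on a saturated chain carbon bound to two saturated chain carbons. Compound 1 `CCOC(=O)C(C(=O)OCC)C(CC(=O)C[C@@H]1O[C@H](CO)[C@@H](O)[C@H](O)[C@H]1O)c1ccccc1` bears phenyl there and in an assay on isolated protein for inhibition of lysosomal alpha-glucosidase (Rattus norvegicus), tested at 100 uM (a lower number here means less inhibition, a higher number more inhibition at the concentration tested (going by the name of the read-out)), compound 1 gives -45%. Compound 2 `CCOC(=O)C(C(=O)OCC)C(CC(=O)C[C@@H]1O[C@H](CO)[C@@H](O)[C@H](O)[C@H]1O)c1ccc(OC)c(OC)c1` bears 3,4-dimethoxyphenyl and gives -2.3%. Compound 3 `CCOC(=O)C(C(=O)OCC)C(CC(=O)C[C@@H]1O[C@H](CO)[C@@H](O)[C@H](O)[C@H]1O)c1ccc2ccccc2c1` bears naphthalen-2-yl and gives -20%. Compound 3 thus stands second highest of the three numbers, with compound 2 nearest and compound 1 furthest, the steps being a number 25 percentage points higher from compound 1 to compound 3 (beyond the scatter) and a number 17.7 percentage points lower from compound 2 to compound 3 (beyond the scatter).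

Compound 4 `CCOC(=O)C(C(=O)OCC)C(CC(=O)C[C@@H]1O[C@H](CO)[C@@H](O)[C@H](O)[C@H]1O)c1cccnc1` is not yet measured. Its change from compound 3: pyridin-3-yl in place of naphthalen-2-yl on a saturated chain carbon bound to two saturated chain carbons. Among the measured compounds shown here, no measured step swaps an aryl group for a six-membered ring with a hetero atom, so the only bearing comes from the aryl swaps already seen: a number 42.7 percentage points higher from compound 1 to compound 2 (beyond the scatter), a number 25 percentage points higher from compound 1 to compound 3 (beyond the scatter) and a number 17.7 percentage points lower from compound 2 to compound 3 (beyond the scatter). Those steps say that a change at this position moves the read-out by a modest to large amount in either direction, and nothing points to a direction here. A step of a number 5 percentage points lower from compound 3 to compound 4 (within the scatter) is therefore expected, within the scatter, with a wide range. Compound 4 is estimated at -25%, with a range from -50% to 0%.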

Compound 4, a percentage reported as inhibition, at one concentration (the size of the read-out at that concentration, not a potency): -20%
For compound 4 the middle estimate is 5 percentage points below the measured one, and the stated range covers the measured number.
By their numbers in this assay, from the lowest: compound 1; then compounds 3 and 4 (each within the scatter of the next); then compound 2.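

In this assay, the first ring with a hetero atom at this place, pyridin-3-yl, matches naphthalen-2-yl (no change at the digits printed from compound 3 to compound 4 (within the scatter)), so a single six-membered aromatic ring with one hetero atom and a hydrogen-bond acceptor reads the same here as two carbon-only aromatic rings with none. Against phenyl, the other single ring in the series, the swap to pyridin-3-yl gives a clear shift (a number 25 percentage points higher from compound 1 to compound 4 (beyond the scatter)), which shows that having one ring rather than two does not by itself set the read-out, while 3,4-dimethoxyphenyl remains separate from pyridin-3-yl (a number 17.7 percentage points lower from compound 2 to compound 4 (beyond the scatter)). Nothing available explains why these groups rank as they do, so the steps stand as observations only.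

As far as these compounds go, it remains open whether the read-out depends on where the ring nitrogen sits, as pyridin-2-yl or pyridin-4-yl would show, or on the hetero atom being in the ring at all, as a phenyl carrying an amine or a carboxylic acid would show. A saturated ring such as cyclohexyl or piperidin-4-yl would show whether an aromatic ring is needed at this place.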